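The source may report more compounds than this note shows. Statements on the series, on what has been measured and on what is new or still open speak of the compounds shown alone.

Values in a functional assay on HT-29 cells (Homo sapiens) for inhibition, read by MTT assay, with a stated time of 48 h; on this read-out lower numbers stand for stronger inhibition and higher numbers for weaker inhibition:
- Compound 1 `COc1cc(-c2cc(-c3cccc([N+](=O)[O-])c3)nc(-c3ccccc3)n2)cc(OC)c1OC`: > 25000 nM
- Compound 2 `COc1cc(-c2cc(-c3ccc(O)cc3)nc(-c3ccccc3)n2)cc(OC)c1OC`: 11300 nM

The entry for compound 1, > 25000 nM, is a limit of the assay and not a number. Going by the values given here, compound 2, at 11300 nM, therefore holds the only true number so far. Compound 3 `COc1cc(-c2cc(-c3ccc(O)cc3O)nc(-c3ccccc3)n2)cc(OC)c1OC` has hydroxy in place of hydrogen on an aromatic carbon, turning 4-hydroxyphenyl into 2,4-dihydroxyphenyl (hydroxy in place of hydrogen on an aromatic carbon). Among the compounds with values here, one measured step touches this same ring: an at least 2.2-fold lower number from compound 1 to compound 2 (0.34 log units; beyond the scatter). That swap is a different one, so it gives only a rough sense of scale: a modest move toward a lower number when the hydroxy group arrived. A small further move in that direction is expected in this assay, possibly no larger than the scatter. The estimated step is a 1.4-fold lower number from compound 2 to compound 3 (0.15 log units; within the scatter). The estimate for compound 3 is 8000 nM, with an expected range from 2500 nM to 25000 nM.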

Compound 3, half-maximal inhibitory concentration: 4960 nM
Compound 3: middle estimate off by 1.6-fold (0.21 log units), on the high side; low and high end bracket the measured number.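

In this assay, a single hydroxy group added ortho to a large group and meta to the existing hydroxy group gives a 2.3-fold lower number from compound 2 to compound 3 (0.36 log units; beyond the scatter). Going by these compounds alone, this is the first step here between two true numbers, so it shows that this position on the ring responds to one added group by a size that can actually be stated. The whole swap of the ring substituents gives an at least 5.0-fold lower number from compound 1 to compound 3 (0.70 log units; beyond the scatter), a size that can only be given as a minimum, as compound 1 holds a limit of the assay and not a number: the limit of > 25000 nM in this assay, at which 1 of the 3 values shown sits.

From the compounds shown here alone, what remains open is whether hydroxy itself matters at this position or whether other groups would serve as well. An amine or a fluorine atom in the same place would help separate these possibilities, and a carboxylic acid would extend the comparison.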